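Solubility of a New Piperidine Analogue Against Its Neighbours

This account rests on a few compounds, and the source may have more. Where it says the series, first, only, none or still open, it means among the compounds named here.

Of the compounds shown here, three sharing one core have been measured in a physicochemical assay for solubility, at pH 7.4; a lower number here means a less soluble compound, a higher number a more soluble compound. Compound 1, with the structure `C=CC(=O)Nc1cc(-n2c(-c3nc(-c4cnn(C5CCN(C)CC5)c4)cnc3N)nc3ccccc32)ccc1OC`, gives in this assay only a limit of < 10000 nM rather than a number. Compound 2, with the structure `C=CC(=O)Nc1cccc(-n2c(-c3nc(-c4cnn(C5CCN(C)CC5)c4)cnc3N)nc3ccncc32)c1`, gives 540000 nM in this assay. Compound 3, with the structure `C=CC(=O)Nc1cccc(-n2c(-c3nc(-c4cnn(CCN5CCN(C)CC5)c4)cnc3N)nc3ccccc32)c1`, gives 30000 nM in this assay, the lowest of the two numbers that are known; the nearest number is that of compound 2, which is a higher one and lies beyond the scatter, and no step between any two of these compounds differs in only one place, so the values are simply shown side by side.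

Compound 4, with the structure `C=CC(=O)Nc1cccc(-n2c(-c3nc(-c4cnn(C5CCN(C(=O)CN(C)C)CC5)c4)cnc3N)nc3ccccc32)c1`, has not yet been measured. It differs from compound 3 in one place: 1-(((dimethylamino)methyl)carbonyl)piperidin-4-yl in place of 2-(4-methylpiperazin-1-yl)ethyl on an aromatic nitrogen. For the measured compounds named here, since no single-point step between measured compounds exists, the size and direction of this change can only be estimated from the structures. A modest decrease, of about the scatter or a little beyond it, is expected, so that the step from compound 3 to compound 4 is estimated as a 2.0-fold lower number from compound 3 to compound 4 (0.30 log units; within the scatter). Compound 4 is therefore expected to give about 15000 nM in this assay, with a likely range from 3000 nM to 70000 nM.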

Compound 4, solubility: 18000 nM
For compound 4 the middle estimate is 1.2-fold (0.08 log units) below the measured one; the range from low to high includes it.
By their numbers in this assay, from the lowest: compounds 4 and 3 (each within the scatter of the next); then compound 2. At a limit, below all of these: compound 1.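

This is the first step among these compounds that changes only one place, so it is the first direct reading of the group on this aromatic nitrogen in this assay. Putting 1-(((dimethylamino)methyl)carbonyl)piperidin-4-yl in place of 2-(4-methylpiperazin-1-yl)ethyl brings 12 heavy atoms instead of 9, a carbonyl, and a six-membered non-aromatic ring with 1 hetero atom instead of 2, yet it gives a 1.7-fold lower number from compound 3 to compound 4 (0.22 log units; within the scatter) and so leaves the two compounds indistinguishable in this measurement. Nothing shown here bears on why these two different groups read alike.

On these data alone, this single pair is all that speaks for the position, so it stays open whether the same exchange would also read alike on the core of compound 1 or the core of compound 2. Also open, as far as these compounds go, is what a morpholine ring, a carboxylic acid or a longer chain ending in a primary amine would give on this aromatic nitrogen, where a step beyond the scatter would show how far a change here can move the number.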